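Chloro to methyl on the aryl ring: second occurrence

This account rests on a few compounds, and the source may have more. Where it says the series, first, only, none or still open, it means among the compounds named here.

Compound 1 `Cc1nn(C)c2c1C(c1cccc(Cl)c1)=NC(C)(C)CN2` is measured in a functional assay on the whole organism for positive allosteric modulation, with Rattus norvegicus as the target (a higher number here means that more compound is needed for the effect, a lower number that less compound is needed), and gives 2.5 mg/kg. Compound 2 `Cc1cccc(C2=NC(C)(C)CNc3c2c(C)nn3C)c1` carries the change methyl in place of chloro on an aromatic carbon and in this assay reaches only a limit, > 10 mg/kg. The resulting step of an at least 4.0-fold higher number from compound 1 to compound 2 (0.60 log units; beyond the scatter) rests on the limit of > 10 mg/kg in this assay, at which 1 of the 3 values shown sits, and is at least modest. Compound 3 `Cc1nn(C)c2c1C(c1ccc(Cl)cc1)=NCCN2` gives 2.5 mg/kg in this assay; the difference between the core of compound 3 and the core of compound 1 is not broken down here. Compound 4 `Cc1ccc(C2=NCCNc3c2c(C)nn3C)cc1` is not yet measured and differs from compound 3 by methyl in place of chloro on an aromatic carbon. This is the same kind of change as before, though the place differs: meta to a large group there, para to a large group here. Expected step for compound 4: a 4.0-fold higher number from compound 3 to compound 4 (0.60 log units; beyond the scatter), weaker activity on the pattern of compound 2. Estimated value for compound 4: 10 mg/kg.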

Compound 4, minimum effective dose: 2.5 mg/kg
Estimate against measurement, compound 4: 4.0-fold (0.60 log units) above; measured number below the stated range.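

In this assay, methyl in place of chloro on an aromatic carbon gives no change at the digits printed from compound 3 to compound 4 (within the scatter), so the change does not carry over as a fixed step between these two cores: the same change on two cores in this assay, an at least 4.0-fold higher number (0.60 log units; beyond the scatter) from compound 1 to compound 2 and no change at the digits printed (within the scatter) from compound 3 to compound 4, at least 4.0-fold (0.60 log units) apart, beyond the scatter of two such steps. The value of compound 2 is a limit and not a number: the limit of > 10 mg/kg in this assay, at which 1 of the 4 values shown sits. The two pairs differ in both the core and the place on the ring, so they do not show which of these goes with the gap.

Still open, as far as these compounds go, is how the change behaves with the same place on both cores. Also open, from the compounds shown here alone, is whether methoxy or trifluoromethyl in place of chloro, para to a large group, would match methyl on the core of compound 3.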